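A few compounds are considered here, and "the series" means these few. Any claim that something is new, unique, unknown or untested is made for them only; others in the source may bear on it.

Series notes. Compound 1 `COc1ccccc1-c1cn(C[C@H](O)[C@H]2OC(=O)C(OCc3ccccc3)=C2OCc2ccccc2)nn1` and compound 2 `Cc1ccc(-c2cn(C[C@H](O)[C@H]3OC(=O)C(OCc4ccccc4)=C3OCc3ccccc3)nn2)cc1` share one core and differ at a single aromatic carbon. In a functional assay on CFPAC-1 cells (Homo sapiens) for antiproliferative activity, read by MTT assay, with a stated time of 72 h (on this read-out lower numbers stand for stronger inhibition and higher numbers for weaker inhibition), compound 1 gives only a limit, > 100000 nM. In this assay compound 2 likewise gives only a limit, > 100000 nM. The step that the two limits leave unreadable from compound 1 to compound 2 is therefore unreadable, since both values sit at the limit of > 100000 nM in this assay, at which 2 of the 2 values shown sit. Compound 2 thus stands at the limit of this assay, with no number of its own and no readable gap to compound 1.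

Compound 3 `CCCCc1cn(C[C@H](O)[C@H]2OC(=O)C(OCc3ccccc3)=C2OCc2ccccc2)nn1` is not yet measured; its change from compound 2 is butyl in place of 4-methylphenyl on an aromatic carbon. For the measured compounds named here, only the step from compound 1 to compound 2 bears on this change, and its size is not readable: it shows merely that replacing one aryl group by another on that aromatic carbon left both values at the limit. Going by the values given here, no measured step gives a direction for the butyl group. The expected step of a number no higher from compound 2 to compound 3 (the limit leaves the size open) is of no readable size, with the value most likely once more a limit. The estimate for compound 3 in this assay is 100000 nM, within 20000 nM to 300000 nM.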

Compound 3, half-maximal inhibitory concentration: 73200 nM
Beside the measured number, compound 3's estimate is 1.4-fold (0.14 log units) above it, within the range that was stated.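

In this assay, for the compounds shown here, compound 3 is the only one of the three compounds with a number of its own, while compound 1 and compound 2 remain limits: the limit of > 100000 nM in this assay, at which 2 of the 3 values shown sit. Replacing the aryl group with butyl on the aromatic carbon of the five-membered aromatic ring therefore gives a readable value at this position, with an at least 1.3-fold lower number from compound 2 to compound 3 (0.13 log units; that floor lies within the scatter) and an at least 1.3-fold lower number from compound 1 to compound 3 (0.13 log units; that floor lies within the scatter). Both steps are floors only, and both floors lie within the scatter, so the result shows that a butyl chain here can give a value inside the range of this assay, but it does not establish how large the change is.

Going by these compounds, the true values of compound 1 and compound 2 remain unknown, so the full size of these two steps cannot be read, and neither can the step between the two aryl compounds. The compounds shown also leave open whether a longer chain such as hexyl, a cyclohexyl ring, or a butyl chain ending in an amine or a carboxylic acid on the same aromatic carbon would lower the number further.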